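Nitro in Place of Diethylamino: An Expected Loss of Potency

The source may hold more compounds than are shown below. What is called first, only, known or untested is meant among the compounds shown, and "the series" means these compounds.

Among the compounds with values here, compound 3 `CCN(CC)c1ccc(/C=C/C(=O)c2ccc(OC)c3c2OC(C)(C)C=C3)cc1` is the only one of the three compounds for which a functional assay on SW-620 cells (Homo sapiens) for antiproliferative activity, read by MTT assay, with a stated time of 24 h (a higher number here means a weaker inhibitor, a lower number a stronger inhibitor), returns a number: compound 3 gives 670 nM. Compound 1 `COc1ccc(C(=O)/C=C/c2ccc(F)cc2)c2c1C=CC(C)(C)O2` reaches only the assay limit, giving > 10000 nM. Compound 2 `COc1ccc(C(=O)/C=C/c2ccc(Br)cc2)c2c1C=CC(C)(C)O2` likewise sits at a limit, with > 10000 nM. Compound 4 `COc1ccc(C(=O)/C=C/c2ccc([N+](=O)[O-])cc2)c2c1C=CC(C)(C)O2` differs from compound 3 by nitro in place of diethylamino on an aromatic carbon. The two measured steps that bear on this change both run toward the diethylamino group, namely an at least 14-fold lower number from compound 1 to compound 3 (1.17 log units; beyond the scatter) and an at least 14-fold lower number from compound 2 to compound 3 (1.17 log units; beyond the scatter), both set against (the limit of > 10000 nM in this assay, at which 2 of the 3 values shown sit). Taking the diethylamino group away is therefore expected to undo that gain, and compound 4 is estimated at 15000 nM, within 3000 nM to 60000 nM, a step of a 22-fold higher number from compound 3 to compound 4 (1.35 log units; beyond the scatter) that is expected to carry it back to the limit.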

Compound 4, half-maximal inhibitory concentration: 3520 nM
Compound 4: middle estimate off by 4.3-fold (0.63 log units), on the high side; the measured number falls inside the stated range.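

Diethylamino is not the only group at this place that returns a number in this assay: nitro in place of fluoro gives an at least 2.8-fold lower number from compound 1 to compound 4 (0.45 log units; beyond the scatter) and nitro in place of bromo gives an at least 2.8-fold lower number from compound 2 to compound 4 (0.45 log units; beyond the scatter) in the same read-out. Diethylamino still keeps the lead, with nitro in its place giving a 5.3-fold higher number from compound 3 to compound 4 (0.72 log units; beyond the scatter) here. The two steps from fluoro and bromo are bounded on one side only: the limit of > 10000 nM in this assay, at which 2 of the 4 values shown sit.

Where a primary amine or a methoxy group would fall at this place remains open. So does whether the ethyl chains matter, which a dimethylamino group would address.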